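Fluorine Out, Chlorine In on a Phenyl Group

This account rests on a few compounds, and the source may have more. Where it says the series, first, only, none or still open, it means among the compounds named here.

In an ADME assay on MT4 cells (Homo sapiens) for cytotoxicity, read by MTT assay (on this read-out higher numbers stand for lower toxicity in this test and lower numbers for higher toxicity in this test), compound 3 `O=C1c2ccccc2C(=O)N1CCOC(=S)N(C(=O)c1cc(F)ccc1F)c1ccc(Cl)cc1` gives 54000 nM, and compound 2 `O=C1c2ccccc2C(=O)N1CCOC(=S)N(C(=O)c1ccc(F)cc1F)c1ccc(Cl)cc1` gives 52000 nM. These two values lie within the usual scatter of each other, so compound 3 stands level with compound 2. Compound 1 `Cc1ccc(C(=O)N(C(=S)OCCN2C(=O)c3ccccc3C2=O)c2ccc(Cl)cc2)cc1` reads > 100000 nM, which is a limit of the assay and not a number.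

Compound 4 `O=C1c2ccccc2C(=O)N1CCOC(=S)N(C(=O)c1ccc(Cl)cc1Cl)c1ccc(Cl)cc1` keeps the shared core and changes one group: 2,4-dichlorophenyl in place of 2,5-difluorophenyl on a carbonyl carbon.

Three measured steps at this same carbonyl carbon bear on the change. Rearranging the two fluorines gave a 1.0-fold higher number from compound 2 to compound 3 (0.02 log units; within the scatter). Replacing 4-methylphenyl with a difluorophenyl group gave an at least 1.9-fold lower number from compound 1 to compound 2 (0.28 log units; that floor lies within the scatter) and an at least 1.8-fold lower number from compound 1 to compound 3 (0.26 log units; that floor lies within the scatter), and both of these sizes are only floors. None of the three shows a change beyond the scatter. Within the data shown here, still, no measured compound carries chlorine on this group, so the new swap remains untested and the range must stay wide.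

The expected change is small, with no step beyond the scatter, and the estimate is a 1.2-fold lower number from compound 3 to compound 4 (0.08 log units; within the scatter). For compound 4 the estimated value is 45000 nM, with an expected range from 18000 nM to 100000 nM.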

Compound 4, half-maximal cytotoxic concentration: 18000 nM
Compound 4: middle estimate off by 2.5-fold (0.40 log units), on the high side, and the stated range covers the measured number.
By their numbers in this assay, from the lowest: compound 4; then compounds 2 and 3 (each within the scatter of the next). At a limit, above all of these: compound 1.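

In this assay, among these compounds, a swap on this carbonyl carbon now gives a change beyond the scatter, which none of the earlier steps had clearly done: a 3.0-fold lower number from compound 3 to compound 4 (0.48 log units; beyond the scatter), and a 2.9-fold lower number from compound 2 to compound 4 (0.46 log units; beyond the scatter). The second of these is the cleaner comparison, since 2,4-difluorophenyl and 2,4-dichlorophenyl differ only in the halogen, and in this small set the lower number, meaning higher toxicity in this test, comes with chlorine rather than with either fluorine arrangement. Against the 4-methylphenyl group the result reads an at least 5.5-fold lower number from compound 1 to compound 4 (0.74 log units; beyond the scatter), a size that is only a floor, as the starting value is a limit and not a number: the limit of > 100000 nM in this assay, at which 1 of the 4 values shown sits.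

Among the compounds shown here, only one chlorine-bearing group appears at this carbonyl carbon, so it remains open whether the lower number follows chlorine in general or belongs to 2,4-dichlorophenyl alone. From the compounds shown here alone, how a 4-chlorophenyl group with its single chlorine, or a 2,4-dibromophenyl group with a heavier halogen, would read on this carbonyl carbon also stays unknown.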